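Shortening the chain substituent across two related cores

The compounds below may be only part of what the source reports. "The series", "measured", "known", "first", "only" and "open" are said of these compounds alone.

Measured in a functional assay on MCF7 cells (Homo sapiens) for inhibition, read by fluorescence, with a stated time of 72 h; on this read-out lower numbers stand for stronger inhibition and higher numbers for weaker inhibition:
- compound 1 `CCCn1cnc2c(NC(=N)N)nc(N)nc21` gives 36500 nM
- compound 2 `CC(C)Cn1cnc2c(NC(=N)N)nc(N)nc21` gives 96600 nM
- compound 3 `CC(C)n1cnc2c(N)nc(N)nc21` gives > 100000 nM

For compound 3 the value is a limit of the assay and not a number. That value sits at the limit of > 100000 nM in this assay, at which 1 of the 3 values shown sits. The difference between the core of compound 2 and the core of compound 3 is not broken down here.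

For the measured compounds named here, the one measured step is a 2.6-fold lower number from compound 2 to compound 1 (0.42 log units; beyond the scatter), the change being (hydrogen in place of methyl on a saturated chain carbon bound to two saturated chain carbons).

Compound 4 `CCn1cnc2c(N)nc(N)nc21` is not yet measured. It differs from compound 3 by hydrogen in place of methyl on a saturated chain carbon bound to an aromatic nitrogen and a saturated chain carbon. This is the same kind of change as the step from compound 2 to compound 1, but the place is not the same: there the carbon is bound to two saturated chain carbons, here it is bound to an aromatic nitrogen and a saturated chain carbon.

The expected step from compound 3 to compound 4 is a step that the limit leaves unreadable from compound 3 to compound 4; this rests on the measured step of a 2.6-fold lower number from compound 2 to compound 1 (0.42 log units; beyond the scatter), set beside the fact that compound 3 starts from a limit, so the number for compound 4 may again be only a limit. Compound 4 is estimated at 120000 nM, with a range from 35000 nM to 400000 nM expected to hold most repeats.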

Compound 4, half-maximal inhibitory concentration: > 100000 nM
Compound 4 ended at the assay's limit (the forecaster's own chance of this, stated with the estimate: 65%); the middle value does not contradict the limit.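

No step can be read between compound 3 and compound 4, from isopropyl to ethyl: in this assay both values are limits of the assay and not numbers, because both sit at the same limit: the limit of > 100000 nM in this assay, at which 2 of the 4 values shown sit. The compounds shown leave open whether hydrogen in place of methyl at this place changes inhibition at all on the core of compound 3.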